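Replacing Bromo with Methyl in Compound 3

The source may hold more compounds than are shown below. What is called first, only, known or untested is meant among the compounds shown, and "the series" means these compounds.

Going by the values given here, compound 2 `Brc1ccc(OC[C@@H]2CCN2)cn1` gives 0.021 nM in an assay on brain for binding affinity to Neuronal acetylcholine receptor; alpha4/beta2 (Rattus norvegicus), read by radioligand binding (a lower number here means a stronger inhibitor, a higher number a weaker inhibitor), the lowest of the two numbers measured so far, while compound 1 `Fc1ccc(OC[C@@H]2CCN2)cn1` gives 0.057 nM. Among the compounds with values here, the one measured step, a 2.7-fold lower number from compound 1 to compound 2 (0.43 log units; beyond the scatter), shows that the group on this ring carbon matters. Compound 3 `Cc1ccc(OC[C@@H]2CCN2)cn1` differs from compound 2 by methyl in place of bromo on an aromatic carbon. Within the data shown here, no measured step covers methyl at this position, so that single step is the only guide. Given a 2.7-fold lower number from compound 1 to compound 2 (0.43 log units; beyond the scatter), a modest step back upward is expected, a 2.4-fold higher number from compound 2 to compound 3 (0.38 log units; beyond the scatter). Compound 3 is therefore estimated at 0.05 nM, with a range from 0.015 nM to 0.15 nM.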

Compound 3, inhibition constant: 0.057 nM
For compound 3 the middle estimate is 1.1-fold (0.06 log units) below the measured one, and the stated range covers the measured number.
By their numbers in this assay, from the lowest: compound 2; then compounds 1 and 3 (each within the scatter of the next).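

In this assay, methyl in place of bromo reverses the gain that bromo gave over fluoro (a 2.7-fold higher number from compound 2 to compound 3 (0.43 log units; beyond the scatter)), while methyl in place of fluoro leaves the number unchanged (no change at the digits printed from compound 1 to compound 3 (within the scatter)). Among these three groups on this ring carbon, only bromo stands apart, and fluoro and methyl cannot be told apart. Nothing measured here explains this difference. As far as these compounds go, whether a chloro group, a nitrile or an amine at this position would match bromo or match fluoro and methyl remains open.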